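Cytotoxicity notes: aryl swap on the acylthiourea carbonyl

The source may report more compounds than this note shows. Statements on the series, on what has been measured and on what is new or still open speak of the compounds shown alone.

Measured so far:
compound 1 `O=C(NC(=S)N1CCc2c(OCCCCCOc3ccc(Cl)cc3)cccc21)c1ccc(Br)cc1` — 29100 nM
compound 2 `O=C(NC(=S)N1CCc2c(OCCCCCOc3ccc(Cl)cc3)cccc21)c1cccs1` — 10700 nM

Both compounds share one core and differ only in the aryl group on the carbonyl carbon. In an ADME assay on Huh-7 cells (Homo sapiens) for cytotoxicity (on this read-out higher numbers stand for lower toxicity in this test and lower numbers for higher toxicity in this test), compound 2 gives the lower of the two numbers; the step of a 2.7-fold lower number from compound 1 to compound 2 (0.43 log units; beyond the scatter) is modest but beyond the scatter.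

Compound 3 `O=C(NC(=S)N1CCc2c(OCCCCCOc3ccc(Cl)cc3)cccc21)c1cccnc1` is not yet measured. Its change from compound 2 is pyridin-3-yl in place of thiophen-2-yl on a carbonyl carbon. Among the compounds with values here, the only step that bears on it is a 2.7-fold lower number from compound 1 to compound 2 (0.43 log units; beyond the scatter), which swaps the aryl group at the same carbonyl carbon and stayed modest in size; no step from a thiophen-2-yl to a pyridin-3-yl group has been measured here. A modest step at most is therefore expected for compound 3, in either direction, with a slight lean toward a higher number. Compound 3 is estimated at 15000 nM, range 6000 nM to 40000 nM, an expected step of a 1.4-fold higher number from compound 2 to compound 3 (0.15 log units; within the scatter).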

Compound 3, half-maximal cytotoxic concentration: 11100 nM
Beside the measured number, compound 3's estimate is 1.4-fold (0.13 log units) above it, within the range that was stated.
By their numbers in this assay, from the lowest: compounds 2 and 3 (each within the scatter of the next); then compound 1.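

In this assay, pyridin-3-yl in place of thiophen-2-yl on the carbonyl carbon gives a 1.0-fold higher number from compound 2 to compound 3 (0.02 log units; within the scatter) and so leaves the read-out within the scatter, which means that a five-membered and a six-membered aromatic ring, each with one hetero atom, cannot be told apart at this position. Pyridin-3-yl in place of 4-bromophenyl gives a 2.6-fold lower number from compound 1 to compound 3 (0.42 log units; beyond the scatter), close in size to a 2.7-fold lower number from compound 1 to compound 2 (0.43 log units; beyond the scatter), so among these three compounds only compound 1 stands apart, by a modest step. No measured information bears on the cause of this grouping.

Open, from the compounds shown here alone, is whether unsubstituted phenyl would group with compound 1 or with compound 2 and compound 3, which would separate the part played by the bromine from that of the ring. Also open, going by these compounds, is how a saturated ring such as cyclohexyl, or a pyridin-3-yl carrying an amine, would read on this carbonyl carbon.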